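The source may hold more compounds than are shown below. What is called first, only, known or untested is meant among the compounds shown, and "the series" means these compounds.

Among the compounds with values here, in a functional assay on HeLa cells (Homo sapiens) for antiproliferative activity, read by MTT assay, with a stated time of 24 h (on this read-out higher numbers stand for weaker inhibition and lower numbers for stronger inhibition), compound 1 (`Sc1nnc(-c2ccc3c(c2)OCCO3)n1-c1ccccc1`) gives 51900 nM and compound 2 (`Fc1ccccc1CSc1nnc(-c2ccc3c(c2)OCCO3)n1-c1ccccc1`) gives 24300 nM, the lower of the two numbers so far. Next in the series is compound 3 (`Fc1ccc(CSc2nnc(-c3ccc4c(c3)OCCO4)n2-c2ccccc2)cc1`), which differs from compound 2 as follows: 4-fluorophenyl in place of 2-fluorophenyl on a saturated chain carbon bound to a sulfur. That is, 4-fluorophenyl stands in place of 2-fluorophenyl on a saturated chain carbon bound to a sulfur. Within the data shown here, no measured step compares these two groups directly. Among the measured compounds shown here, the only step that bears on the change is a 2.1-fold lower number from compound 1 to compound 2 (0.33 log units; beyond the scatter), a modest one that brought in the whole 2-fluorobenzyl group. The exchange in compound 3 keeps a fluorobenzyl group in place, so a smaller shift than that one is expected, with no clear direction and nothing beyond the scatter. The expected step is a 1.1-fold lower number from compound 2 to compound 3 (0.02 log units; within the scatter). For compound 3 the estimate is 23000 nM, with an expected range of 11000 nM to 50000 nM.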

Compound 3, half-maximal inhibitory concentration: 46900 nM
For compound 3 the middle estimate is 2.0-fold (0.31 log units) below the measured one; the measured number falls inside the stated range.
By their numbers in this assay, from the lowest: compounds 2, 3 and 1 (each within the scatter of the next, the first and the last beyond it).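

In this assay the exchange of 2-fluorophenyl for 4-fluorophenyl on a saturated chain carbon bound to a sulfur gives a 1.9-fold higher number from compound 2 to compound 3 (0.29 log units; within the scatter) and so does not separate the two fluorobenzyl groups. Measured against hydrogen on the sulfur, 4-fluorobenzyl gives a 1.1-fold lower number from compound 1 to compound 3 (0.04 log units; within the scatter) while 2-fluorobenzyl gives a 2.1-fold lower number from compound 1 to compound 2 (0.33 log units; beyond the scatter) and only the latter step is beyond the scatter, so a fluorobenzyl group on the sulfur does not by itself ensure a step beyond the scatter. Nothing in the available data explains these numbers.

Still open, on these data alone, is whether the step from hydrogen depends on where the fluorine stands, which a 3-fluorobenzyl group or an unsubstituted benzyl group would help to test. Also open, as far as these compounds go, is whether a different group on the sulfur, such as a longer alkyl chain or a chain ending in a carboxylic acid, would give a larger step.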